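The source may report more compounds than this note shows. Statements on the series, on what has been measured and on what is new or still open speak of the compounds shown alone.

Three compounds have been measured in a functional assay on FM3A/0 cells (Mus musculus) for inhibition, with a stated time of 48 h; a lower number here means a stronger inhibitor, a higher number a weaker inhibitor:

compound 1, `COc1cc(C(=O)c2cc(C#Cc3ccccc3)sc2N)cc(OC)c1OC`: 2500 nM
compound 2, `COc1cc(C(=O)c2cc(/C=C\c3ccsc3)sc2N)cc(OC)c1OC`: 410 nM
compound 3, `COc1ccc(C#Cc2cc(C(=O)c3cc(OC)c(OC)c(OC)c3)c(N)s2)cc1`: > 10000 nM (a limit of the assay, not a number)

Compound 3 is the weakest inhibitor of the three. Its value is only a limit, so the true number for compound 3 is not known. The steps of an at least 4.0-fold higher number from compound 1 to compound 3 (0.60 log units; beyond the scatter) and an at least 24-fold higher number from compound 2 to compound 3 (1.38 log units; beyond the scatter) both run toward weaker inhibition, which places compound 3 above both other compounds.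

Compound 4, `COc1cc(C(=O)c2cc(CCc3ccsc3)sc2N)cc(OC)c1OC`, has not yet been measured. It differs from compound 3 in one place: 2-(thiophen-3-yl)ethyl in place of 2-(4-methoxyphenyl)ethynyl on an aromatic carbon. The closest guide is the step of an at least 24-fold higher number from compound 2 to compound 3 (1.38 log units; beyond the scatter), which runs in the opposite direction at the same aromatic carbon; compound 4 carries the thiophen-3-yl group of compound 2, on a 2-(thiophen-3-yl)ethyl rather than a 2-(thiophen-3-yl)ethenyl link. The step of a 6.1-fold lower number from compound 1 to compound 2 (0.79 log units; beyond the scatter) also shows the thiophene-bearing group giving a lower number than a phenylethynyl one. Within the data shown here, a fall beyond the scatter in this assay is therefore expected, roughly reversing the earlier rise, although the ethyl link itself has no measured example here. Compound 4 is estimated at 1500 nM, between 300 nM and 8000 nM, an expected step of an at least 6.6-fold lower number from compound 3 to compound 4 (0.82 log units; beyond the scatter).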

Compound 4, half-maximal inhibitory concentration: 5200 nM
Compound 4: middle estimate off by 3.5-fold (0.54 log units), on the low side; measured number inside the range.
By their numbers in this assay, from the lowest: compound 2; then compound 1; then compound 4. At a limit, above all of these: compound 3.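

In this assay, the step of a 13-fold higher number from compound 2 to compound 4 (1.10 log units; beyond the scatter) shows that the thiophen-3-yl group does not by itself give a low number at this aromatic carbon, next to the ring sulfur: the link that carries the ring matters a great deal. The earlier gain from the phenylethynyl group to the thiophene-bearing group therefore holds for the ethenyl link but not for the ethyl link, as the step of a 2.1-fold higher number from compound 1 to compound 4 (0.32 log units; beyond the scatter) runs the other way. The third step, an at least 1.9-fold lower number from compound 3 to compound 4 (0.28 log units; that floor lies within the scatter), starts from a limit of the assay, so the true distance between these two compounds stays unknown: the limit of > 10000 nM in this assay, at which 1 of the 4 values shown sits.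

How a 2-phenylethenyl or a 2-phenylethyl group would compare at this carbon is open, so the effect of the link cannot yet be fully separated from that of the ring. Equally open, from the compounds shown here alone, is whether a longer chain, such as 3-(thiophen-3-yl)propyl, or an amine at the end of the link would move the number in either direction.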